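Trading trifluoromethyl for methoxy on a second core

The source may hold more compounds than are shown below. What is called first, only, known or untested is meant among the compounds shown, and "the series" means these compounds.

Compound 1 `COc1cc2c(Oc3ccc(NC(=O)c4cc(-c5ccc(C(F)(F)F)cc5)ccn4)cc3F)ccnc2cc1OCCCN1CCCCC1` is tested in a functional assay on NCI-H460 cells (Homo sapiens) for cytotoxicity, read by MTT assay, with a stated time of 72 h (a lower number here means a stronger inhibitor, a higher number a weaker inhibitor), and gives 360 nM. Compound 2 `COc1ccc(-c2ccnc(C(=O)Nc3ccc(Oc4ccnc5cc(OCCCN6CCCCC6)c(OC)cc45)c(F)c3)c2)cc1` differs from it by methoxy in place of trifluoromethyl on an aromatic carbon and in this assay compound 2 gives 200 nM, a step of a 1.8-fold lower number from compound 1 to compound 2 (0.26 log units; within the scatter). Compound 3 `COc1cc2c(Oc3ccc(NC(=O)c4cc(-c5ccc(C(F)(F)F)cc5)ccn4)cc3F)ccnc2cc1OCCCN1CCCC1` carries a different core, the difference being (pyrrolidin-1-yl in place of piperidin-1-yl on a saturated chain carbon, three bonds along the chain from an oxygen on an aromatic ring), and in this assay compound 3 gives 250 nM, a step of a 1.4-fold lower number from compound 1 to compound 3 (0.16 log units; within the scatter). Compound 4 `COc1ccc(-c2ccnc(C(=O)Nc3ccc(Oc4ccnc5cc(OCCCN6CCCC6)c(OC)cc45)c(F)c3)c2)cc1` has not yet been measured; it differs from compound 3 by methoxy in place of trifluoromethyl on an aromatic carbon, the same change that separates compound 1 from compound 2. For compound 4 the expected step is a 1.7-fold lower number from compound 3 to compound 4 (0.22 log units; within the scatter), resting on the earlier step of a 1.8-fold lower number from compound 1 to compound 2 (0.26 log units; within the scatter) and the starting value of compound 3, 250 nM. Compound 4 is therefore estimated at 150 nM in this assay, expected to lie between 80 nM and 280 nM.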

Compound 4, half-maximal inhibitory concentration: 200 nM
Beside the measured number, compound 4's estimate is 1.3-fold (0.12 log units) below it; the measured number falls inside the stated range.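

In this assay, methoxy in place of trifluoromethyl gives a 1.3-fold lower number from compound 3 to compound 4 (0.10 log units; within the scatter), and the change reads alike on the two cores: the same change on two cores in this assay, a 1.8-fold lower number (0.26 log units; within the scatter) from compound 1 to compound 2 and a 1.3-fold lower number (0.10 log units; within the scatter) from compound 3 to compound 4, 1.4-fold (0.16 log units) apart, within the scatter of two such steps. Pyrrolidin-1-yl in place of piperidin-1-yl gives no change at the digits printed from compound 2 to compound 4 (within the scatter), and this change also reads alike on both: the same change on two cores in this assay, a 1.4-fold lower number (0.16 log units; within the scatter) from compound 1 to compound 3 and no change at the digits printed (within the scatter) from compound 2 to compound 4, 1.4-fold (0.16 log units) apart, within the scatter of two such steps. Each change therefore carries from one core to the other without a detectable difference, but every step lies within the scatter, so this does not show that either change has a real effect, and two cores cannot establish a rule for the whole series.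

Still open, going by these compounds, is whether another group on the same aromatic carbon, such as an amine or a carboxylic acid, would give a step beyond the scatter. The same question stands for a morpholine ring or a longer chain in place of the pyrrolidin-1-yl or piperidin-1-yl end.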